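Swapping a Vinyl for a Tert-Butyl Group

The source may hold more compounds than are shown below. What is called first, only, known or untested is meant among the compounds shown, and "the series" means these compounds.

Compound 1 `COc1cc(-c2ccnc3cc(-c4ccc(F)cc4)nn23)cc(OC)c1OC` gives 5840 nM in a functional assay on HeLa cells (Homo sapiens) for inhibition, read by CCK-8 assay, with a stated time of 48 h; on this read-out higher numbers stand for weaker inhibition and lower numbers for stronger inhibition.
Compound 2 `C=Cc1ccc(-c2cc3nccc(-c4cc(OC)c(OC)c(OC)c4)n3n2)cc1` gives 882 nM in this assay.

Of these two numbers compound 2 has the lower one, separated from compound 1 by the step of a 6.6-fold lower number from compound 1 to compound 2 (0.82 log units; beyond the scatter). Compound 3 `COc1cc(-c2ccnc3cc(-c4ccc(C(C)(C)C)cc4)nn23)cc(OC)c1OC` has not yet been measured. It differs from compound 2 in one place: tert-butyl in place of vinyl on an aromatic carbon. For the measured compounds named here, the only measured step, a 6.6-fold lower number from compound 1 to compound 2 (0.82 log units; beyond the scatter), concerns a different exchange at the same aromatic carbon and offers no direct guide to how tert-butyl compares with vinyl; it shows only that an exchange at this carbon can move the number well beyond the scatter. With no closer comparison available, the expected step of a 1.7-fold higher number from compound 2 to compound 3 (0.23 log units; within the scatter) is small, could go in either direction, and is quite uncertain. Compound 3 is therefore estimated at 1500 nM, with a range from 400 nM to 6000 nM.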

Compound 3, half-maximal inhibitory concentration: > 10000 nM
Compound 3: only a limit was reported; the forecaster's own chance of this, stated with the estimate: 5%; middle value at least 6.6-fold (0.82 log units) from the limit.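

Compound 3 gives only a limit of the assay, not a number: the limit of > 10000 nM in this assay, at which 1 of the 3 values shown sits.

Even with that limit, the change reads as an at least 11-fold higher number from compound 2 to compound 3 (1.05 log units; beyond the scatter), which shows that this aromatic carbon can separate two groups built of carbon alone, neither with hydrogen-bond donors or acceptors. A carbon-only group here therefore does not by itself keep the number low. Against fluoro the change reads as an at least 1.7-fold higher number from compound 1 to compound 3 (0.23 log units; that floor lies within the scatter), so all that can be said of tert-butyl against fluoro is that the floor of this gap does not clear the scatter.

From the compounds shown here alone, how far the true value of compound 3 lies past the limit remains unknown. Also open, going by these compounds, is how smaller carbon groups such as ethyl or isopropyl would read at this carbon, and how an amine or a carboxylic acid would read there.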